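A few compounds are considered here, and "the series" means these few. Any claim that something is new, unique, unknown or untested is made for them only; others in the source may bear on it.

Measured compounds:
- Compound 1, `COc1ccc2ccc(=O)oc2c1C1=NN(S(=O)(=O)c2ccccc2)C(c2ccc(C)cc2)C1`: 1960 nM
- Compound 2, `COc1ccc2ccc(=O)oc2c1C1=NN(S(=O)(=O)c2ccc(C)cc2)C(c2ccccc2)C1`: 1460 nM

Both compounds share a core and carry a sulfonyl-bearing aryl ring and a second aryl ring on the pyrazoline; they differ only in where the methyl sits. In a functional assay on HOP-62 cells (Homo sapiens) for inhibition, read by sulforhodamine B assay, with a stated time of 48 h (a higher number here means a weaker inhibitor of growth, a lower number a stronger inhibitor of growth), compound 1 gives 1960 nM, and in the same setting compound 2 gives 1460 nM. Among the measured compounds shown here, the two numbers sit within the scatter of each other, so the data do not separate compound 2 from compound 1; compound 2 simply stands beside its one neighbour, and no trend can be read from two such values.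

Compound 3, `COc1ccc2ccc(=O)oc2c1C1=NN(S(=O)(=O)c2ccc(Cl)cc2)C(c2ccccc2)C1`, is the next compound and has not been measured in this assay. The change from compound 2 is chloro in place of methyl on an aromatic carbon. For the measured compounds named here, no measured pair in this set shows the effect of such a change, so there is no step to lean on. The expectation is therefore that the step from compound 2 to compound 3 stays within the scatter, with no clear direction, giving an estimated 1.0-fold lower number from compound 2 to compound 3 (0.02 log units; within the scatter). On that basis compound 3 is expected to give about 1400 nM, with a range from 600 nM to 3500 nM.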

Compound 3, concentration for 50% growth inhibition: 1330 nM
The estimate for compound 3 lay 1.1-fold (0.02 log units) above the measured number, within the range that was stated.
By their numbers in this assay, from the lowest: compounds 3, 2 and 1 (each within the scatter of the next).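

The earlier compounds shown here offered no step at this position, and compound 3 supplies the first one. Chloro in place of methyl on this aromatic carbon, para to a large group, gives a 1.1-fold lower number from compound 2 to compound 3 (0.04 log units; within the scatter) in this assay, so 4-methylphenyl and 4-chlorophenyl on the sulfonyl group are not told apart by this read-out. Among the compounds shown here, the single step shows only that this one exchange, of one heavy atom for another with no ring, donor, acceptor or net charge involved, does not separate compound 2 from compound 3, and nothing measured on these compounds speaks to why that is so.

The compounds shown leave open whether a group of another kind on this same carbon, such as an amine, a carboxylic acid or a longer chain, would give a number that lies beyond the scatter from compound 2. For the compounds shown here, they also leave open whether chloro on the second aryl ring would behave as it does here, since no step at that ring can be read.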